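Adding a bromine to the weakest of two pyrazoline-oxindole hybrids

A few compounds are considered here, and "the series" means these few. Any claim that something is new, unique, unknown or untested is made for them only; others in the source may bear on it.

Measured so far:
compound 1 `COc1ccc(C2CC(c3ccccc3)=NN2C2=NC(=O)/C(=C3\C(=O)Nc4ccc(Br)cc43)S2)cc1` gives 200 nM
compound 2 `COc1ccc(C2=NN(C3=NC(=O)/C(=C4\C(=O)Nc5ccccc54)S3)C(c3ccc(OC)cc3)C2)cc1` gives 81500 nM

In a functional assay on cells (Cancer cell lines, Homo sapiens) for cytotoxicity, read by sulforhodamine B assay, with a stated time of 48 h (a higher number here means a weaker inhibitor of growth, a lower number a stronger inhibitor of growth), compound 2 stands highest of the two, far beyond the scatter from compound 1. The two differ in more than one place, so their values alone do not tell which change matters. Compound 3 `COc1ccc(C2=NN(C3=NC(=O)/C(=C4\C(=O)Nc5ccc(Br)cc54)S3)C(c3ccc(OC)cc3)C2)cc1` keeps the core of compound 2 and differs by bromo in place of hydrogen on an aromatic carbon, the same group that compound 1 also carries. A sizeable drop in this assay is expected, though well short of compound 1. The estimate for compound 3 is 15000 nM, between 2000 nM and 80000 nM, a step of a 5.4-fold lower number from compound 2 to compound 3 (0.74 log units; beyond the scatter).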

Compound 3, concentration for 50% growth inhibition: 210 nM
Estimate against measurement, compound 3: 71-fold (1.85 log units) above, outside the stated range (below it).
By their numbers in this assay, from the lowest: compounds 1 and 3 (each within the scatter of the next); then compound 2.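

In this assay bromo in place of hydrogen on an aromatic carbon of the fused two-ring system brings a 390-fold lower number from compound 2 to compound 3 (2.59 log units; beyond the scatter) and turns a poor growth inhibitor into a strong one. With bromo present, the swap that brings in methoxy gives a 1.1-fold higher number from compound 1 to compound 3 (0.02 log units; within the scatter) and stays within the scatter, so that change makes no measurable difference here. Nothing measured here explains the effect of bromo. Still open, going by these compounds, is whether chloro or an amine on the same carbon would match bromo. Also open, on these data alone, is whether the methoxy change stays as silent where hydrogen replaces bromo.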